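The compounds below may be only part of what the source reports. "The series", "measured", "known", "first", "only" and "open" are said of these compounds alone.

Measured in a functional assay on MCF7 cells (Homo sapiens) for antiproliferative activity, read by MTT assay, with a stated time of 48 h; on this read-out higher numbers stand for weaker inhibition and lower numbers for stronger inhibition:

- Compound 1 `C=C1[C@H](O)[C@@H](O)[C@@H](O)C(C)(C)/C=C/[C@H](C)[C@H](OC(=O)c2ccccc2)[C@@]2(O)C[C@@](C)(O)[C@H](OC(C)=O)[C@@H]2[C@H]1OCC(C)C`: > 100000 nM
- Compound 2 `CC(=O)O[C@@H]1[C@@H]2[C@@H](OCC(C)C)C3(CO3)[C@H](O)[C@@H](O)[C@@H](O)C(C)(C)/C=C/[C@H](C)[C@H](OC(=O)c3ccccc3)[C@@]2(O)C[C@@]1(C)O`: > 100000 nM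
- Compound 3 `C=C1[C@H](OC(C)=O)[C@@H](OC(C)=O)[C@@H](O)C(C)(C)/C=C/[C@H](C)[C@H](OC(=O)c2ccccc2)[C@@]2(O)C[C@@](C)(O)[C@H](OC(C)=O)[C@@H]2[C@H]1OCC(C)C`: > 100000 nM

None of these three entries is a number, and each one is a limit of the assay. The series as a whole shows this: the limit of > 100000 nM in this assay, at which 3 of the 3 values shown sit. Compound 3 therefore has no exact position, and its entry of > 100000 nM is a limit.

Compound 4 `C=C1[C@H](OC(C)=O)[C@@H](OC(C)=O)[C@@H](OC(C)=O)C(C)(C)/C=C/[C@H](C)[C@H](OC(=O)c2ccccc2)[C@@]2(O)C[C@@](C)(O)[C@H](OC(C)=O)[C@@H]2[C@H]1OCC(C)C` has not yet been measured. It departs from compound 3 in one place, with acetyl in place of hydrogen on an oxygen on a saturated carbon, a change of hydroxy to acetoxy: acetyl in place of hydrogen on an oxygen on a saturated carbon.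

Among the compounds with values here, no measured pair shows what this change does. The expectation in this assay is therefore for no step beyond the scatter, in either direction, and for compound 4 to remain close to the limit reached by compound 3.

Compound 4 is estimated at 100000 nM, with an expected range from 30000 nM to 200000 nM. This estimate amounts to an expected a number no higher from compound 3 to compound 4 (the limit leaves the size open).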

Compound 4, half-maximal inhibitory concentration: > 100000 nM
Compound 4: a limit, no number; the forecaster's own chance of this, stated with the estimate: 65%; the middle value lies on the limit itself.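

In this assay compound 4 gives > 100000 nM, which is a limit and not a number. Within the data shown here, compound 3 also stands at a limit, so no step between compound 3 and compound 4 can be read. The compounds shown leave open what the change of hydroxy to acetoxy does, and the whole series offers no exact value to compare: the limit of > 100000 nM in this assay, at which 4 of the 4 values shown sit.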